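This account rests on a few compounds, and the source may have more. Where it says the series, first, only, none or still open, it means among the compounds named here.

Two compounds have so far been taken through a physicochemical assay for solubility, at pH 7; on this read-out higher numbers stand for higher solubility and lower numbers for lower solubility. Compound 1 `CC(=O)N1CCN(C(=O)N2Cc3c(NC(=O)c4ccc(F)cc4)n[nH]c3C2(C)C)CC1` gives > 225000 nM, a limit and not a number. Compound 2 `CC(C)(C)C(=O)N1Cc2c(NC(=O)C3CCNCC3)n[nH]c2C1(C)C` gives > 225000 nM, which is likewise a limit. Compound 2 therefore has no exact figure of its own, and the whole record so far is the limit of > 225000 nM in this assay, at which 2 of the 2 values shown sit. Among the measured compounds shown here, no measured step is available to serve as a guide.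

Compound 3 `CC(C)(C)C(=O)N1Cc2c(NC(=O)c3cccnc3)n[nH]c2C1(C)C` has not yet been measured. It differs from compound 2 in one place, with pyridin-3-yl in place of piperidin-4-yl on a carbonyl carbon. Since compound 2 gives > 225000 nM, the result for compound 3 in this assay can only be expected to stay at that same limit or to come in lower. The expectation here is a moderate fall, though with little certainty, and a second result at the limit would not be a surprise. The estimated change is an at least 1.8-fold lower number from compound 2 to compound 3 (0.27 log units; that floor lies within the scatter). For compound 3 the expected value is 120000 nM, with an estimated range from 30000 nM to 225000 nM.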

Compound 3, solubility: 207000 nM
The estimate for compound 3 lay 1.7-fold (0.24 log units) below the measured number; low and high end bracket the measured number.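

In this assay, putting pyridin-3-yl in place of piperidin-4-yl on a carbonyl carbon gives an at least 1.0-fold lower number from compound 2 to compound 3 (0.03 log units; that floor lies within the scatter), so the exchange of a non-aromatic ring for an aromatic one shows no change beyond the scatter at this position. Compound 3 also supplies the first exact figure in the series, 207000 nM. The earlier compounds shown here offered only limits. Compound 2 remains a limit and not a number, so the step carries only a floor, and the record at the limit still reads: the limit of > 225000 nM in this assay, at which 2 of the 3 values shown sit.

The compounds shown leave open how large the true gap between compound 2 and compound 3 is, since that floor says nothing about its upper size. They also leave open whether another group on this carbonyl carbon, such as an open-chain amine, a carboxylic acid or a longer alkyl chain, would give a number clearly apart from that of compound 3, and whether the same exchange would read alike on a different group at the other end of the core.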